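A few compounds are considered here, and "the series" means these few. Any claim that something is new, unique, unknown or untested is made for them only; others in the source may bear on it.

Compound 1 `CS(=O)(=O)c1cncc(-c2cnc3ccc(-c4cccc(S(=O)(=O)C5CC5)c4)nn23)c1` is measured in a physicochemical assay for solubility, at pH 2 (a higher number here means a more soluble compound, a lower number a less soluble compound), and compound 1 gives 18000 nM. Among the two numbers given this is the highest; the nearest is compound 2 `NC(=O)c1ccc(-c2cnc3ccc(-c4cccc(S(=O)(=O)C5CC5)c4)nn23)cc1`, where compound 2 gives 6300 nM, after a step of a 2.9-fold lower number from compound 1 to compound 2 (0.46 log units; beyond the scatter). Compound 3 `CS(=O)(=O)c1ccc(-c2cnc3ccc(-c4cccc(C(=O)NCCO)c4)nn23)cc1` gives only a limit of the assay, > 200000 nM, which is the limit of > 200000 nM in this assay, at which 1 of the 3 values shown sits, and not a number. Compound 4 `CS(=O)(=O)c1cccc(-c2ccc3ncc(-c4cncc(S(C)(=O)=O)c4)n3n2)c1` differs from compound 1 by methyl in place of cyclopropyl on a sulfonyl sulfur. Going by the values given here, no measured step shares this change; the one measured step swaps a different group, so it shows only the scale of steps seen so far. Compound 4 is therefore expected to move by a 1.4-fold higher number from compound 1 to compound 4 (0.14 log units; within the scatter), near the scatter. The expected value for compound 4 is 25000 nM, within a range from 8000 nM to 70000 nM.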

Compound 4, solubility: 16000 nM
Estimate against measurement, compound 4: 1.6-fold (0.19 log units) above; measured number inside the range.
By their numbers in this assay, from the lowest: compound 2; then compounds 4 and 1 (each within the scatter of the next). At a limit, above all of these: compound 3.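

Going by these compounds alone, putting methyl in place of cyclopropyl on a sulfonyl sulfur gives the first measured step at this place in this assay (a 1.1-fold lower number from compound 1 to compound 4 (0.05 log units; within the scatter)). Unlike the earlier step, which swapped a different group, this one stays inside the scatter, so for this pair the three-membered ring can be replaced by methyl with no readable difference. Nothing measured here gives a reason for this result. From the compounds shown here alone, an amine or a longer chain on the sulfonyl sulfur remains open, and so does whether this swap reads the same on compound 2.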